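A few compounds are considered here, and "the series" means these few. Any claim that something is new, unique, unknown or untested is made for them only; others in the source may bear on it.

Working notes on the series. Compound 1 `C#CC(=O)N1C(c2cccc(F)c2)SC[C@@H]1C(=O)OCC` is the starting point here. In a functional assay on Huh-7 cells (Homo sapiens) for inhibition, read by sulforhodamine B assay (a higher number here means a weaker inhibitor, a lower number a stronger inhibitor), compound 1 gives 1400 nM. Its companion is compound 2 `C#CC(=O)N1C(c2ccc(C#N)cc2)SC[C@@H]1C(=O)OCC`, which in this assay gives 2600 nM. The two numbers lie within the scatter of each other, so on the values shown compound 1 and compound 2 cannot be told apart, and neither can be called the stronger of the pair. The only variation measured so far is in the aryl group on the saturated ring carbon of the shared core, and across that variation nothing has moved beyond the scatter.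

The next compound, compound 3 `C#CC(=O)N1C(C(CC)CCCC)SC[C@@H]1C(=O)OCC`, leaves the aromatic series altogether: 1-ethylpentyl in place of 3-fluorophenyl on a saturated ring carbon. Going by the values given here, no measured step speaks to a change of this kind; both measured compounds carry a six-membered aromatic ring at that position, and neither shows what a branched chain does there. The expectation is therefore set loosely, leaning toward a weaker inhibitor.

For compound 3 the step from a 2.1-fold higher number from compound 1 to compound 3 (0.33 log units; beyond the scatter) is expected to be a modest loss, not firmly beyond the scatter. In this assay compound 3 is expected at about 3000 nM, with a plausible range from 800 nM to 12000 nM.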

Compound 3, half-maximal inhibitory concentration: 1700 nM
For compound 3 the middle estimate is 1.8-fold (0.25 log units) above the measured one; the measured number falls inside the stated range.
By their numbers in this assay, from the lowest: compounds 1, 3 and 2 (each within the scatter of the next).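

Replacing 3-fluorophenyl with 1-ethylpentyl on the saturated ring carbon gives a 1.2-fold higher number from compound 1 to compound 3 (0.08 log units; within the scatter) in this assay and so leaves the number inside the scatter. Compound 1 and compound 2 both carry a six-membered aromatic ring at this position, so they could not show whether that ring matters; compound 3, with a branched chain and no ring, shows that an aromatic ring at this position is not needed for a number in the range of those two compounds in this assay. Nothing available explains why the change from the ring to the chain leaves the number within the scatter.

Still open, as far as these compounds go, is how far this position accepts other groups, such as a straight hexyl chain, a methyl group, a longer chain than 1-ethylpentyl, or a chain ending in an amine or a carboxylic acid. Also open, from the compounds shown here alone, is whether the ethynylcarbonyl and ethoxycarbonyl groups of the shared core can be exchanged as freely as the group on this ring carbon.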